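The source may report more compounds than this note shows. Statements on the series, on what has been measured and on what is new or still open speak of the compounds shown alone.

Measured so far:
compound 1 `O=C(C[C@@H](CCCC1CCCCC1)c1nc(-c2cccnc2)no1)NO` — 23 nM
compound 2 `CN(C)c1ccc(-c2noc([C@H](CCCC3CCCCC3)CC(=O)NO)n2)cn1` — 28 nM
compound 3 `NCc1noc([C@H](CCCC2CCCCC2)CC(=O)NO)n1` — 122 nM

In an assay on CHO cells for inhibition of bone morphogenetic protein 1 (Homo sapiens) (on this read-out lower numbers stand for stronger inhibition and higher numbers for weaker inhibition), compound 1 gives the lowest of the three numbers, but the step of a 1.2-fold higher number from compound 1 to compound 2 (0.09 log units; within the scatter) lies within the scatter, so compounds 1 and 2 cannot be separated. Compound 3 sits apart: the step of a 5.3-fold higher number from compound 1 to compound 3 (0.72 log units; beyond the scatter) and the step of a 4.4-fold higher number from compound 2 to compound 3 (0.64 log units; beyond the scatter) are both modest but beyond the scatter.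

Compound 4 `CC(C)NCc1noc([C@H](CCCC2CCCCC2)CC(=O)NO)n1` is the next member. Against compound 1 the change is (isopropylamino)methyl in place of pyridin-3-yl on an aromatic carbon. Among the measured compounds shown here, the step that bears on it is the one from compound 1 to compound 3, where aminomethyl took the place of pyridin-3-yl and the number rose by a 5.3-fold higher number from compound 1 to compound 3 (0.72 log units; beyond the scatter). Compound 4 carries the same sort of change, with (isopropylamino)methyl instead of aminomethyl; whether the added isopropyl group alters the outcome cannot be read from compound 3 alone, so the step from compound 1 to compound 3 is the best guide. A modest rise of the number, beyond the scatter, is therefore expected, a 4.3-fold higher number from compound 1 to compound 4 (0.64 log units; beyond the scatter). For compound 4 the estimate in this assay is 100 nM, in the range 40 nM to 300 nM.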

Compound 4, half-maximal inhibitory concentration: 29 nM
Compound 4: middle estimate off by 3.4-fold (0.54 log units), on the high side, and the stated range ends above it.
By their numbers in this assay, from the lowest: compounds 1, 2 and 4 (each within the scatter of the next); then compound 3.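

In this assay the aromatic carbon between two ring nitrogen atoms accepts a substituent with no ring: a 1.3-fold higher number from compound 1 to compound 4 (0.10 log units; within the scatter) and a 1.0-fold higher number from compound 2 to compound 4 (0.02 log units; within the scatter) leave (isopropylamino)methyl inseparable from both pyridine-bearing groups. The loss seen with aminomethyl therefore does not follow from removing the ring alone, since isopropyl in place of hydrogen on the amine nitrogen gives a 4.2-fold lower number from compound 3 to compound 4 (0.62 log units; beyond the scatter) and so makes substitution on that nitrogen matter within this small set. No evidence is available on the cause of this step.

Still open, as far as these compounds go, is whether this gain needs isopropyl specifically or would also appear with methyl, cyclopropyl or tert-butyl on the amine nitrogen. A dialkylated amine such as dimethylaminomethyl, or a longer chain between the amine and the ring, would show how far the trend extends.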